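Swapping the ring on nitrogen in compound 2

The source may hold more compounds than are shown below. What is called first, only, known or untested is meant among the compounds shown, and "the series" means these compounds.

Measured in a functional assay on HOS-TE85 cells (Homo sapiens) for inhibition, read by CCK-8 assay, with a stated time of 72 h; on this read-out lower numbers stand for stronger inhibition and higher numbers for weaker inhibition:
- Compound 1 `CCN(CC)c1ccc(N2C(=O)CSC2c2cccc(C(=O)NCCCCc3ccccc3)c2)cc1`: > 1000 nM
- Compound 2 `O=C(NCCCCn1cccn1)c1cccc(C2SCC(=O)N2c2cc(Br)ccn2)c1`: 105 nM
- Compound 3 `COc1cccc(OC)c1N1C(=O)CSC1c1cccc(C(=O)NCCCCc2ccccc2)c1`: > 1000 nM

For the measured compounds named here, compound 2 gives 105 nM, the only true number in this small set. The other results stand at the limit of > 1000 nM in this assay, at which 2 of the 3 values shown sit. Each of these two results is a limit of the assay, not a number.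

The next compound, compound 4 `O=C(NCCCCn1cccn1)c1cccc(C2SCC(=O)N2c2cccc(C3CC3)c2)c1`, keeps the rest of compound 2 and changes one group: 3-cyclopropylphenyl in place of 4-bromopyridin-2-yl on an amide-type nitrogen in a ring. In words, 3-cyclopropylphenyl takes the place of 4-bromopyridin-2-yl on an amide-type nitrogen in a ring.

Going by the values given here, only one measured step touches this place, a step that the two limits leave unreadable from compound 1 to compound 3. Both of its ends are limits, so it offers no size to borrow. Among the compounds with values here, no measured step starts from compound 2, which leaves the forecast loose.

One weak hint remains. Compound 4 carries a substituted phenyl at this place, as does compound 1 at > 1000 nM, a limit. Some loss of inhibition in this assay therefore seems more likely than a gain, though a gain cannot be excluded.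

The estimated size is a 2.1-fold higher number from compound 2 to compound 4 (0.32 log units; beyond the scatter), towards weaker inhibition. For compound 4 the expected value is 220 nM, with an estimated range of 45 nM to 1000 nM.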

Compound 4, half-maximal inhibitory concentration: 299 nM
Estimate against measurement, compound 4: 1.4-fold (0.13 log units) below; the measured number falls inside the stated range.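

In this assay, for the compounds shown here, putting 3-cyclopropylphenyl in place of 4-bromopyridin-2-yl on the amide-type nitrogen in the ring gives a 2.8-fold higher number from compound 2 to compound 4 (0.45 log units; beyond the scatter), and this is the first step at this position with a size that can be read. Going by these compounds alone, the only earlier step here joins two limits and cannot be read, so it said nothing about how much this position responds to a change of group. The new step shows that a ring of carbon only, carrying a cyclopropyl group, can stand here at a modest cost, and that compound 4 keeps a true number instead of joining the results that sit at a limit: the limit of > 1000 nM in this assay, at which 2 of the 4 values shown sit.

This single step changes the ring nitrogen, the bromine and the cyclopropyl group all at once, and the compounds shown cannot separate what each of these contributes. Going by these compounds, a 4-bromophenyl group would keep the bromine without the ring nitrogen, and a plain pyridin-2-yl group would keep the ring nitrogen without the bromine, so how each would read at this position remains open.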